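Replacing nitro with chloro in compound 3

A few compounds are considered here, and "the series" means these few. Any claim that something is new, unique, unknown or untested is made for them only; others in the source may bear on it.

In an ADME assay on Vero cells (Chlorocebus sabaeus) for inhibition (on this read-out higher numbers stand for lower toxicity in this test and lower numbers for higher toxicity in this test), compound 1 (`COc1ccc(/C=C2\CCC/C(=C\c3ccc(OC)cc3)C2=O)cc1`) gives 178000 nM, compound 2 (`COc1ccc(/C=C2\CCC/C(=C\c3ccccc3)C2=O)cc1`) gives 291000 nM and compound 3 (`COc1ccc(/C=C2\CCC/C(=C\c3ccc([N+](=O)[O-])cc3)C2=O)cc1`) gives 435000 nM. Compound 3 therefore stands apart from only one of the other two: the data show a 2.4-fold higher number from compound 1 to compound 3 (0.39 log units; beyond the scatter), but just a 1.5-fold higher number from compound 2 to compound 3 (0.17 log units; within the scatter). Compound 4 (`COc1ccc(/C=C2\CCC/C(=C\c3ccc(Cl)cc3)C2=O)cc1`) carries chloro in place of nitro on an aromatic carbon, para to a large group: chloro in place of nitro on an aromatic carbon. The other swaps at this place moved the number little, with a 1.6-fold higher number from compound 1 to compound 2 (0.21 log units; within the scatter) as the third example. Among the compounds with values here, no chloro compound has been measured yet, so a small drop at most seems likely in this assay, and none beyond the scatter. The expected change is a 1.6-fold lower number from compound 3 to compound 4 (0.19 log units; within the scatter). For compound 4 the estimated value is 280000 nM, with an expected range of 140000 nM to 520000 nM.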

Compound 4, half-maximal cytotoxic concentration: 401000 nM
Estimate against measurement, compound 4: 1.4-fold (0.16 log units) below; the measured number falls inside the stated range.
By their numbers in this assay, from the lowest: compounds 1, 2, 4 and 3 (each within the scatter of the next, the first and the last beyond it).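

Chloro cannot be told apart from nitro or from hydrogen at this place in this assay given a 1.1-fold lower number from compound 3 to compound 4 (0.04 log units; within the scatter) and a 1.4-fold higher number from compound 2 to compound 4 (0.14 log units; within the scatter) as steps inside the scatter. Against methoxy the swap gives a 2.3-fold higher number from compound 1 to compound 4 (0.35 log units; beyond the scatter) as a modest step beyond the scatter, the same picture nitro gave, so chloro and nitro both separate from methoxy while hydrogen does not.

On these data alone, whether an amine or a carboxylic acid at this place would move the number further remains open. No measurement on hand offers a reason for this pattern.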